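The compounds below may be only part of what the source reports. "The series", "measured", "known", "first", "only" and "open" are said of these compounds alone.

For the measured compounds named here, in a physicochemical assay for solubility, read by LC-MS, measured as thermodynamic solubility, at pH 6.8 (on this read-out lower numbers stand for lower solubility and higher numbers for higher solubility), only two compounds have been read so far. Compound 1 `CCC(=O)N1CC[C@H](Oc2ncnc3c2CN(c2cnc(OC)c(C(F)(F)F)c2)CC3)C1` gives 80000 nM, a measured number. Compound 2 `COc1ccc(N2CCc3ncnc(-c4cccc(C(=O)N5CCN(C(C)=O)CC5)c4)c3C2)cn1` has no number, only a limit of the assay, > 1000000 nM. Going by the values given here, its true position is therefore not known, and the two compounds differ in more than one place, so their readings show no single structural step.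

Compound 3 `COc1ccc(N2CCc3ncnc(-c4cccc(OC5CCN(C(C)=O)CC5)c4)c3C2)cn1` has not yet been measured. It keeps the rest of compound 2 but carries (1-acetylpiperidin-4-yl)oxy in place of (4-acetylpiperazin-1-yl)carbonyl on an aromatic carbon.

Among the compounds with values here, no measured pair shows what such a swap does. Within the data shown here, the only numerical reading available is that of compound 1 at 80000 nM, so the expectation for the new compound is drawn towards that number. A fall in this assay beyond the usual scatter is expected, with the estimated step being an at least 5.0-fold lower number from compound 2 to compound 3 (0.69 log units; beyond the scatter). A reading at the limit again remains possible. Compound 3 is estimated at 200000 nM, with an expected range of 40000 nM to 1000000 nM.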

Compound 3, solubility: > 1000000 nM
Compound 3: a limit, no number (the forecaster's own chance of this, stated with the estimate: 15%); middle value at least 5.0-fold (0.69 log units) from the limit.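

Compound 3, like compound 2, gives only a limit and no number in this assay, so no step can be read between these two compounds: the limit of > 1000000 nM in this assay, at which 2 of the 3 values shown sit.

The compounds shown leave open whether (1-acetylpiperidin-4-yl)oxy in place of (4-acetylpiperazin-1-yl)carbonyl on an aromatic carbon changes the reading at all, and if so, in which direction and by how much.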